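This account rests on a few compounds, and the source may have more. Where it says the series, first, only, none or still open, it means among the compounds named here.

Measured so far:
compound 1 `Fc1cccc(CCCN[C@H]2C3C4CC5C6C4CC3C6C52)c1` gives 24.9 nM in an assay on brain for displacement of a labelled ligand from Sigma non-opioid intracellular receptor 1 (Rattus norvegicus); a lower number here means a stronger inhibitor, a higher number a weaker inhibitor
compound 2 `COc1ccc(CN(C)[C@H]2C3C4CC5C3C(=O)C3C5C4C32)cc1OC` gives 1040 nM in this assay

Compound 1 holds the lower of the two inhibition constants; compound 2 sits well beyond the scatter from it. Compound 3 `CN(CCCc1cccc(F)c1)[C@H]1C2C3CC4C5C3CC2C5C41` differs from compound 1 by methyl in place of hydrogen on an amine nitrogen. Within the data shown here, no step of this kind between two measured compounds is available, so the size of the change in this assay is open; for methyl in place of hydrogen on an amine nitrogen a small shift, within or close to the scatter, is expected, slightly toward a lower number. Compound 3 is expected at 15 nM, between 5 nM and 60 nM, a step of a 1.7-fold lower number from compound 1 to compound 3 (0.22 log units; within the scatter).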

Compound 3, inhibition constant: 429 nM
For compound 3 the middle estimate is 29-fold (1.46 log units) below the measured one, and the stated range ends below it.
By their numbers in this assay, from the lowest: compound 1; then compound 3; then compound 2.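

In this assay, methyl in place of hydrogen on this amine nitrogen proves to be a large change, with a 17-fold higher number from compound 1 to compound 3 (1.24 log units; beyond the scatter). Among these compounds, this is the first step read at this position, and it shows that the single added carbon alone moves the number well beyond the scatter, though this one pair speaks only for this chain and core. Nothing shown bears on why the number rises. Going by these compounds, whether an ethyl group or an acetyl group on the same nitrogen would give a similar rise remains open.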